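The source may report more compounds than this note shows. Statements on the series, on what has been measured and on what is new or still open speak of the compounds shown alone.

Measured in an ADME assay on cells (Erythrocyte, Homo sapiens), read by spectrophotometry and hemolysis, with a stated time of 24 h; a higher number here means a weaker inhibitor, a lower number a stronger inhibitor:
- compound 1 `C=CCNC(=S)N/N=C/c1ccc(OCc2ccc3no[n+]([O-])c3c2)cc1`: "nd(insoluble)" (no result reported)
- compound 2 `N=C(N)N/N=C\c1ccccc1OCc1ccc2no[n+]([O-])c2c1`: 58 uM

Only compound 2 has a number in this assay, so compound 2 stands alone at 58 uM, with nothing to rank it against. The other entry, compound 1, gives no result. The compound still to be measured is compound 3 `[O-][n+]1onc2ccc(COc3ccccc3/C=N\NC(=S)Nc3ccccc3)cc21`. Its difference from compound 2 is a group of 9 heavy atoms (7 carbon, 1 nitrogen, 1 sulfur; one six-membered aromatic ring of carbon only) in place of a group of 3 heavy atoms (1 carbon, 2 nitrogen; no ring), on an amine nitrogen: a larger group with one six-membered aromatic ring of carbon only replaces a smaller group with no ring, on an amine nitrogen. Among the measured compounds shown here, no pair of measured compounds shows a step of this kind, so the data offer no direct guide to its size. A modest step towards a lower number in this assay is expected, though this is a cautious judgement with a wide margin. Compound 1, which also holds a sulfur, gives "nd(insoluble)" (no result reported), so a report without a number remains possible for compound 3. The estimated value for compound 3 is 28 uM, with an expected range of 8 uM to 100 uM. This estimate means an expected 2.1-fold lower number from compound 2 to compound 3 (0.32 log units; beyond the scatter).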

Compound 3, concentration for 50% inhibition: > 200 uM
Compound 3: no number, only a limit (the forecaster's own chance of this, stated with the estimate: 35%); middle value at least 7.1-fold (0.85 log units) from the limit.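

In this assay, compound 3 gives > 200 uM, which is a limit of the assay and not a number. With compound 1 reporting no number, this is the only step shown on the amine nitrogen, and it gives a direction: putting the group of 9 heavy atoms, with its one six-membered aromatic ring of carbon only and its sulfur, in place of the ringless group of 3 heavy atoms gives an at least 3.4-fold higher number from compound 2 to compound 3 (0.53 log units; beyond the scatter), so here the larger group moves the read-out towards a higher number, and the step lies beyond the scatter. The size of this step is a bound and not a measured distance, and it stays open on the upper side: the limit of > 200 uM in this assay, at which 1 of the 3 values shown sits.

The entering group differs from the leaving one in both its aromatic ring and its sulfur, so this single step cannot tell which of the two goes with the higher number. A methyl group in place of the aromatic ring, or an oxygen in place of the sulfur, on the same amine nitrogen would separate the two, and a number for compound 3 itself would still be needed to fix the size of the step.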